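Lengthening the ester chain in a carbamate ACAT series

The source may report more compounds than this note shows. Statements on the series, on what has been measured and on what is new or still open speak of the compounds shown alone.

Compound 1 `CC(C)c1cccc(C(C)C)c1OC(=O)NC(=O)OCc1ccccc1`: 77 nM
Compound 2 `CCCCCCOC(=O)NC(=O)Oc1c(C(C)C)cccc1C(C)C`: 53 nM

Of the compounds shown here, two have been measured in an assay on microsomes from intestine for inhibition of acyl-CoA:cholesterol acyltransferase (Oryctolagus cuniculus); a higher number here means a weaker inhibitor, a lower number a stronger inhibitor. Compound 1 gives 77 nM, and compound 2 gives 53 nM; the step of a 1.5-fold lower number from compound 1 to compound 2 (0.16 log units; within the scatter) lies within the scatter, so the two numbers are not distinguished. Among the compounds with values here, compound 2 thus stands at the lower of the two numbers, with compound 1 its only neighbour and within the scatter of it.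

Compound 3 `CCCCCCCCCCOC(=O)NC(=O)Oc1c(C(C)C)cccc1C(C)C` has not yet been measured in this assay. It differs from compound 2 by butyl in place of hydrogen on a saturated chain carbon, six bonds along the chain from an oxygen next to a carbonyl group. Within the data shown here, the only measured step, the one from compound 1 to compound 2, also changed the group on the ester chain and stayed within the scatter; no measured step bears directly on a longer chain. Compound 3 is therefore expected to show no change beyond the scatter, an estimated step of a 1.2-fold lower number from compound 2 to compound 3 (0.07 log units; within the scatter). The expected value for compound 3 in this assay is 45 nM, with a range of 15 nM to 150 nM.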

Compound 3, half-maximal inhibitory concentration: 74 nM
Compound 3: the middle estimate sits 1.6-fold (0.22 log units) below what was measured; low and high end bracket the measured number.
By their numbers in this assay, from the lowest: compounds 2, 3 and 1 (each within the scatter of the next).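

Butyl in place of hydrogen on the saturated chain carbon, six bonds along the chain from an oxygen next to a carbonyl group, gives a 1.4-fold higher number from compound 2 to compound 3 (0.14 log units; within the scatter) in this assay, so this position takes the butyl with no difference that can be read. Nonyl in place of phenyl on the saturated chain carbon bound to an oxygen next to a carbonyl group gives a 1.0-fold lower number from compound 1 to compound 3 (0.02 log units; within the scatter), so the phenyl and the nonyl are not told apart either, and all three ester groups shown fall within the scatter. Nothing at hand offers an explanation for this flat result.

The compounds shown leave open whether a longer chain, or a chain ending in an amine or a carboxylic acid, would move the number beyond the scatter. On these data alone, whether changes on the shared core would do so also stays open.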